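The compounds below may be only part of what the source reports. "The series", "measured", "known", "first", "only" and "open" are said of these compounds alone.

Measured compounds:
- compound 1, `O=C(CCCCCCCCCCCc1ccccc1)CC(=O)N[C@H]1CCOC1=O`, gives 27000 nM in a functional assay on NCI-H630 cells (Homo sapiens) for cytotoxicity, read by sulforhodamine B assay, with a stated time of 5 days; a lower number here means a stronger inhibitor, a higher number a weaker inhibitor
- compound 2, `O=C(CCCCCCCCCCc1ccccc1)CC(=O)N[C@H]1CCOC1=O`, gives 14000 nM in this assay
- compound 3, `O=C(CCCCCCCCc1ccccc1)N[C@H]1CCOC1=O`, gives only a limit of the assay, > 100000 nM, in this assay

Compound 4, `O=C(CCCCCCCCCc1ccccc1)N[C@H]1CCOC1=O`, has not yet been measured in this assay.

Compound 1 and compound 2 differ in one place: benzyl in place of phenyl on a saturated chain carbon, ten or more bonds along the chain from a carbonyl carbon. The measured step that this change made, a 1.9-fold higher number from compound 2 to compound 1 (0.29 log units; within the scatter), is one that repeated measurements of this kind could produce on their own, so the two values say nothing about a real change in potency.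

Compound 4 stands to compound 3 in the same kind of relation: benzyl in place of phenyl on a saturated chain carbon, eight bonds along the chain from a carbonyl carbon. For the measured compounds named here, the change is of the same kind as the one between compound 2 and compound 1, not the same, since the place along the chain from the carbonyl carbon differs between the two cases, as the two descriptions of the differences show. The difference between the two cores, that of compound 3 and that of compound 2, is not broken down here.

For compound 4 the expected step from compound 3 is a step that the limit leaves unreadable from compound 3 to compound 4, a step kept small because a 1.9-fold higher number from compound 2 to compound 1 (0.29 log units; within the scatter) was within the scatter. Compound 3 gives only a limit, so the estimate for compound 4 rests on that limit, and because the limit of > 100000 nM in this assay, at which 1 of the 3 values shown sits, is where compound 3 sits, compound 4 is expected to give about 150000 nM in this assay, estimated between 60000 nM and 400000 nM, very likely reported again only as a limit.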

Compound 4, half-maximal inhibitory concentration: > 100000 nM
Compound 4 gave a limit, no number; the forecaster's own chance of this, stated with the estimate: 75%; the middle value does not contradict the limit.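

Compound 4 gives > 100000 nM as a limit of the assay in this assay and not as a number. Compound 3 gives a limit too, so no step can be read from compound 3 to compound 4: the limit of > 100000 nM in this assay, at which 2 of the 4 values shown sit.

The compounds shown leave open whether benzyl in place of phenyl at this place on the chain changes potency at all.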